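The source may hold more compounds than are shown below. What is called first, only, known or untested is meant among the compounds shown, and "the series" means these compounds.

Values measured in a functional assay on NCI-H292 cells (Homo sapiens) for inhibition, read by MTT assay, with a stated time of 72 h; a lower number here means a stronger inhibitor, a higher number a weaker inhibitor:

- compound 1 `CCCO[C@@H]1C=CC(=O)[C@@H](CO)O1`: 15600 nM
- compound 2 `O=C1C=C[C@@H](OC2CCCC2)O[C@@H]1CO`: 19800 nM
- compound 3 `O=C1C=C[C@@H](OC2CCCCC2)O[C@@H]1CO`: 2600 nM

Compound 2, at 19800 nM, sits level with compound 1 within the scatter of repeat measurements. Compound 3 gives a clearly lower number, 2600 nM, and so is a stronger inhibitor than compound 2.

The next compound to consider is compound 4 `CCO[C@@H]1C=CC(=O)[C@@H](CO)O1`, which has ethyl in place of cyclopentyl on an oxygen on a saturated carbon. Among the compounds with values here, only one measured step bears directly on this change, and it also swaps the cyclopentyl group for an open chain, here in the other direction. That step, with cyclopentyl in place of propyl, was a 1.3-fold higher number from compound 1 to compound 2 (0.10 log units; within the scatter). Since ethyl is also an open chain, compound 4 is expected to read much like compound 1 and compound 2 in this assay, with no shift beyond the scatter. Compound 3, at 2600 nM, carries a different ring on that oxygen and stands well apart, so the range is kept wide. The expected change is a 1.0-fold higher number from compound 2 to compound 4 (0.00 log units; within the scatter), which is an estimate and not a measurement. For compound 4 the estimated value is 20000 nM, with an expected range from 9000 nM to 45000 nM.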

Compound 4, half-maximal inhibitory concentration: 18000 nM
For compound 4 the middle estimate is 1.1-fold (0.05 log units) above the measured one; low and high end bracket the measured number.
By their numbers in this assay, from the lowest: compound 3; then compounds 1, 4 and 2 (each within the scatter of the next).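

In this assay, ethyl in place of cyclopentyl on the oxygen gives a 1.1-fold lower number from compound 2 to compound 4 (0.04 log units; within the scatter) and going from the propyl chain to the ethyl chain gives a 1.2-fold higher number from compound 1 to compound 4 (0.06 log units; within the scatter) so neither removing the ring nor changing the chain length moves the number measurably. Within the data shown here, the earlier compounds offered only one comparison between an open chain and a ring, whereas ethyl, propyl and cyclopentyl now all read alike at this position, and the pattern holds for these three compounds only, since compound 3 with its different ring on that oxygen stands apart at 2600 nM in the same assay. No measurement here explains why these three groups read alike or why the ring of compound 3 differs from them.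

The compounds shown leave open whether a longer chain such as hexyl, or a chain ending in an amine or a carboxylic acid, would stay level with these three or move towards compound 3. They also leave open whether a phenyl ring or a seven-membered carbon ring on the same oxygen would read like compound 3 or like compound 2 in this assay and so whether the low number of compound 3 is confined to that one ring.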